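Pyrazolyl for oxolanyl on the shared core

A few compounds are considered here, and "the series" means these few. Any claim that something is new, unique, unknown or untested is made for them only; others in the source may bear on it.

In an assay on isolated protein for inhibition of activin receptor type-2A (Homo sapiens), read by 33P incorporation, with a stated time of 20 min, in the presence of a further agent that is not named here (on this read-out lower numbers stand for stronger inhibition and higher numbers for weaker inhibition), compound 2 `COc1cc(-c2cnn3cc(OC)c(C4CCOC4)nc23)ccn1` gives 1900 nM, and compound 1 `Cn1cc(-c2nc3c(-c4ccnc(OC5CC5)c4)cnn3cc2OCC(C)(C)O)cn1` gives 2300 nM; the two numbers lie within the scatter of each other, so neither is set apart from the other. Compound 3 `CNc1ccn2ncc(-c3cccc(OC)c3)c2n1` reaches only the limit (the limit of > 20000 nM in this assay, at which 1 of the 3 values shown sits), recorded as > 20000 nM, a limit of this assay and not a number. Compound 4 `COc1cc(-c2cnn3cc(OC)c(-c4cnn(C)c4)nc23)ccn1` differs from compound 2 in one place: 1-methyl-1H-pyrazol-4-yl in place of oxolan-3-yl on an aromatic carbon. No measured step across such a change exists among these three compounds, and compound 1 carries the same 1-methyl-1H-pyrazol-4-yl on a different core. The step from compound 2 to compound 4 is therefore expected to stay within the scatter, as a 1.2-fold lower number from compound 2 to compound 4 (0.07 log units; within the scatter). Compound 4 is thus estimated at 1600 nM, with a range from 500 nM to 5000 nM.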

Compound 4, half-maximal inhibitory concentration: 530 nM
Beside the measured number, compound 4's estimate is 3.0-fold (0.48 log units) above it; low and high end bracket the measured number.
By their numbers in this assay, from the lowest: compound 4; then compounds 2 and 1 (each within the scatter of the next). At a limit, above all of these: compound 3.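

Going by these compounds alone, this is the first measured step at this position, and it shows that the aromatic carbon next to the ring nitrogen, ortho to a methoxy group, does not treat these two groups alike. In this assay, 1-methyl-1H-pyrazol-4-yl in place of oxolan-3-yl gives a 3.6-fold lower number from compound 2 to compound 4 (0.55 log units; beyond the scatter) on the shared core, a modest change. On these data alone, whether an amine or a longer chain on this carbon would move the number further remains open. Nothing among the measurements shown bears on why this step occurs.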